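The source may report more compounds than this note shows. Statements on the series, on what has been measured and on what is new or still open speak of the compounds shown alone.

Measured so far in an ADME assay on RD cells (Homo sapiens) for cytotoxicity, read by neutral red uptake, with a stated time of 3 days; on this read-out higher numbers stand for lower toxicity in this test and lower numbers for higher toxicity in this test:
- Compound 1 `CC(C)Oc1cc(C(=O)NCCCN(C)C)c2ccccc2n1`: 122000 nM
- Compound 2 `CC(C)Oc1cc(C(=O)NC2CCN(C)CC2)c2ccccc2n1`: 101000 nM

In this assay, compound 2 gives 101000 nM, which lies within the scatter of compound 1 at 122000 nM. Neither compound therefore stands apart on these numbers.

The next compound to be tested is compound 3 `CC(C)Oc1cc(C(=O)NCCN)c2ccccc2n1`. Its structural change from compound 2 is 2-aminoethyl in place of 1-methylpiperidin-4-yl on an amide-type nitrogen.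

Among the measured compounds shown here, only one measured step bears on this change, as it alters a group at the same place: a 1.2-fold lower number from compound 1 to compound 2 (0.08 log units; within the scatter). That step is small and stays within the scatter. For the measured compounds named here, no measured compound carries the 2-aminoethyl group, so this evidence is thin and the range must stay wide. On this basis, no step beyond the scatter is expected in this assay, and no direction can be favoured.

The estimate amounts to an expected 1.1-fold lower number from compound 2 to compound 3 (0.03 log units; within the scatter). For compound 3 the estimated value is 95000 nM, with an expected range from 40000 nM to 220000 nM.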

Compound 3, half-maximal cytotoxic concentration: 149000 nM
Estimate against measurement, compound 3: 1.6-fold (0.20 log units) below; the measured number falls inside the stated range.
By their numbers in this assay, from the lowest: compounds 2, 1 and 3 (each within the scatter of the next).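

In this assay, the group on the amide-type nitrogen now changes more widely than it did between the first two compounds: 2-aminoethyl in place of 1-methylpiperidin-4-yl removes the six-membered non-aromatic ring and leaves 3 heavy atoms instead of 7, and the result is a 1.5-fold higher number from compound 2 to compound 3 (0.17 log units; within the scatter). The open-chain comparison points the same way, since amino in place of (dimethylamino)methyl on a saturated chain carbon, two bonds along the chain from an amide-type nitrogen, gives a 1.2-fold higher number from compound 1 to compound 3 (0.09 log units; within the scatter). On these three compounds, neither the ring nor the size of the group separates one number from another in this read-out, and no measurement at hand speaks to what lies behind these numbers.

Going by these compounds, all three groups on the amide-type nitrogen carry an amine, so it remains open whether a plain ethyl chain or a carboxylic acid at the chain end would stay equally close to these values. The isopropoxy group and the rest of the shared core are also the same throughout, which leaves open what a methoxy group in its place would do.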